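A few compounds are considered here, and "the series" means these few. Any claim that something is new, unique, unknown or untested is made for them only; others in the source may bear on it.

Compound 1, `C[C@@H](CC(=O)O)CC(=O)c1c([C@@H](O)CCCCCc2ccccc2)n(C)c2ccc(Cl)cc12`, stands at the weaker end of the two measured compounds in a functional assay for antagonist activity at Oxoeicosanoid receptor 1 (Homo sapiens), read by fluorescence and calcium flux, with stated times of 2 min and 1 min; on this read-out higher numbers stand for weaker inhibition and lower numbers for stronger inhibition: compound 1 gives 120 nM. For the measured compounds named here, the only other number belongs to compound 2, `CC(CC(=O)O)CC(=O)c1c(CCCCCCc2ccccc2)n(C)c2ccc(Cl)cc12`, which in this assay gives 0.28 nM. Going by the values given here, these two compounds differ in more than one place, so their values show only that compound 2 sits far below compound 1, well beyond the scatter, and do not say which part of the structure accounts for that.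

Compound 3, `C[C@H](CC(=O)O)CC(=O)c1c([C@@H](O)CCCCCc2ccccc2)n(C)c2ccc(Cl)cc12`, has not yet been measured. Its relation to compound 1 is the two compounds have the same atoms and bonds and differ only in configuration as drawn: 1 of 2 stereo elements differ; a stereocentre at a saturated chain carbon is drawn R in compound 1 and S in compound 3. Among the compounds with values here, no measured pair here shows what turning over that one stereocentre does in this assay; compound 2 is drawn without a fixed configuration at that carbon and differs elsewhere as well. Inversions of this kind can leave a number roughly in place or move it either way, and the expected step is a 2.4-fold lower number from compound 1 to compound 3 (0.38 log units; beyond the scatter), a modest move toward a lower number, resting only on compound 1 giving 120 nM and possibly being the less favoured arrangement. Compound 3 is therefore estimated at 50 nM, with a likely range from 8 nM to 300 nM.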

Compound 3, half-maximal inhibitory concentration: 0.38 nM
Beside the measured number, compound 3's estimate is 130-fold (2.12 log units) above it, and the stated range ends above it.
By their numbers in this assay, from the lowest: compounds 2 and 3 (each within the scatter of the next); then compound 1.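

For the compounds shown here, compounds 1 and 3 form the first pair here that differs in a single place, so one change can finally be read on its own. In this assay the step is a 320-fold lower number from compound 1 to compound 3 (2.50 log units; beyond the scatter), which makes the S arrangement at this saturated chain carbon by far the better of the two, while the other stereocentre stays as drawn. The whole gap can be assigned to this one stereocentre, because nothing else separates the two structures: the fact that compounds 1 and 3 differ only in the configuration as drawn

The compounds shown do not reveal how the number responds to inverting the other stereocentre, the chain carbon that carries the hydroxyl, nor what that hydroxyl contributes by itself, since compound 2 differs from compound 3 in more than one place. They also leave open whether the S centre would keep its advantage with an ethyl group in place of the methyl on that chain carbon, and how a compound with hydrogen there would compare.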